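Swapping an Amide Substituent in Four Related Compounds

The compounds below may be only part of what the source reports. "The series", "measured", "known", "first", "only" and "open" are said of these compounds alone.

Compound 1 `Cc1ccc(Cn2cc(CSC(=S)N3CCN(C(=O)NC(C)C)CC3)nn2)cc1` and compound 2 `CCN(C)C(=O)N1CCN(C(=S)SCc2cn(Cc3ccc(C)cc3)nn2)CC1` share one core and differ in a single spot: ethyl(methyl)amino in place of isopropylamino on a carbonyl carbon. Compound 3 `COc1cc(Cn2cc(CSC(=S)N3CCN(C(=O)NC(C)C)CC3)nn2)cc(OC)c1OC` is built on a different core, and the difference between the two cores is not broken down here. Compound 4 `CCN(C)C(=O)N1CCN(C(=S)SCc2cn(Cc3cc(OC)c(OC)c(OC)c3)nn2)CC1` relates to compound 3 exactly as compound 2 relates to compound 1, the same change at the same place: ethyl(methyl)amino in place of isopropylamino on a carbonyl carbon.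

In a functional assay on SMMC-7721 cells (Homo sapiens) for cytotoxicity, read by MTT assay, with a stated time of 72 h (on this read-out higher numbers stand for weaker inhibition and lower numbers for stronger inhibition), compound 1 gives > 128000 nM, which is a limit of the assay rather than a number. In this assay compound 2 gives > 128000 nM, again only a limit. In this assay compound 3 gives > 128000 nM, also a limit. The step that the two limits leave unreadable from compound 1 to compound 2 cannot be sized because of the limit of > 128000 nM in this assay, at which 3 of the 3 values shown sit.

For compound 4 the step that the limit leaves unreadable from compound 3 to compound 4 is expected to be unreadable in the same way, since compound 3 sits at > 128000 nM and the identical change gave a step that the two limits leave unreadable from compound 1 to compound 2. Compound 4 is therefore estimated at 200000 nM, within a range from 100000 nM to 600000 nM, most likely reported only as a limit.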

Compound 4, half-maximal inhibitory concentration: > 128000 nM
Compound 4 was reported as a limit; the forecaster's own chance of this, stated with the estimate: 85%; the middle value lies beyond the limit too.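

Within the data shown here, no step can be sized from compound 3 to compound 4, so swapping isopropylamino for ethyl(methyl)amino shows no readable effect, because both compounds sit at a limit rather than a number: (the limit of > 128000 nM in this assay, at which 4 of the 4 values shown sit). The compounds shown leave open whether these two groups differ at all in this assay on a compound that gives an actual number.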